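The source may hold more compounds than are shown below. What is called first, only, known or untested is meant among the compounds shown, and "the series" means these compounds.

Measured so far:
compound 1, `COc1cc(-c2nn(-c3cccc(NC(=O)Nc4cc(C(F)(F)F)cc(C(F)(F)F)c4)c3)cc2-c2ccncc2)ccc1Cl`: 1610 nM
compound 2, `COc1cc(-c2nn(-c3cccc(NC(=O)Nc4ccc(Cl)c(Cl)c4)c3)cc2-c2ccncc2)ccc1Cl`: 6460 nM
compound 3, `O=C(Nc1cccc(-n2cc(-c3ccncc3)c(-c3ccc(Cl)c(O)c3)n2)c1)Nc1ccc(Cl)c(Cl)c1`: a limit, > 32500 nM

In a functional assay on HT-29 cells (Homo sapiens) for inhibition, read by sulforhodamine B assay, with a stated time of 48 h (a higher number here means a weaker inhibitor of growth, a lower number a stronger inhibitor of growth), compound 1 gives 1610 nM, the lowest of the two numbers. Compound 2 gives a higher number, 6460 nM. For compound 3 the assay reports only a limit, > 32500 nM. Compound 3 thus sits at the limit of > 32500 nM in this assay, at which 1 of the 3 values shown sits. How the cores of compound 1 and compound 2 differ is not broken down here. Compound 3 differs from compound 2 in one place, (hydrogen in place of methyl on an oxygen on an aromatic ring), and that change produced an at least 5.0-fold higher number from compound 2 to compound 3 (0.70 log units; beyond the scatter). The unmeasured compound 4, `O=C(Nc1cccc(-n2cc(-c3ccncc3)c(-c3ccc(Cl)c(O)c3)n2)c1)Nc1cc(C(F)(F)F)cc(C(F)(F)F)c1`, carries the same change relative to compound 1, (hydrogen in place of methyl on an oxygen on an aromatic ring). The step expected from compound 1 to compound 4 is a 7.5-fold higher number from compound 1 to compound 4 (0.87 log units; beyond the scatter), which rests on compound 2 and its measured step of an at least 5.0-fold higher number from compound 2 to compound 3 (0.70 log units; beyond the scatter). Compound 4 is therefore estimated at 12000 nM, between 4000 nM and 40000 nM.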

Compound 4, concentration for total growth inhibition: 1870 nM
Beside the measured number, compound 4's estimate is 6.4-fold (0.81 log units) above it; the whole stated range lies above it.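

In this assay, the change from methoxy to hydroxy gave a 1.2-fold higher number from compound 1 to compound 4 (0.07 log units; within the scatter), so the two compounds of this pair cannot be told apart. The change therefore did not carry the same size of step from one core to the other: the same change on two cores in this assay, an at least 5.0-fold higher number (0.70 log units; beyond the scatter) from compound 2 to compound 3 and a 1.2-fold higher number (0.07 log units; within the scatter) from compound 1 to compound 4, at least 4.3-fold (0.63 log units) apart, beyond the scatter of two such steps

For compound 3 the value, > 32500 nM, is a limit, and two pairs cannot show how the change would behave on any further core.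

The compounds shown hold only methoxy or hydroxy at this place on the 4-chloro-3-methoxyphenyl group. On these data alone, it remains open how an ethoxy group, a longer chain on that oxygen or an amine in place of the hydroxy would read on either core.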